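The compounds below may be only part of what the source reports. "The series", "measured", "known", "first", "only" and "open" are said of these compounds alone.

Measured so far:
compound 1 `CCCOc1ccc(C(=O)/C=C/c2ccc(C(=O)Nc3cccc(-c4cc(C(=O)OC)no4)c3)cc2)cc1` — > 40 ug/mL, a limit of the assay
compound 2 `COC(=O)c1cc(-c2cccc(NC(=O)c3ccc(/C=C/C(=O)c4cccc(Br)c4)cc3)c2)on1` — > 100 ug/mL, a limit of the assay

Both values come from an ADME assay on Vero cells (Chlorocebus sabaeus) for cytotoxicity, read by MTT assay, with a stated time of 72 h; a lower number here means that less compound is tolerated, a higher number that more compound is tolerated. Compound 1 gives only a limit there, (the limit of > 40 ug/mL in this assay, at which 1 of the 2 values shown sits). Compound 2 likewise gives only a limit, (the limit of > 100 ug/mL in this assay, at which 1 of the 2 values shown sits). The step that the two limits leave unreadable from compound 1 to compound 2, in which 3-bromophenyl replaces 4-propoxyphenyl on a carbonyl carbon, therefore has no readable size. For the measured compounds named here, compound 2 thus stands at a limit, and the one other value shown is a limit as well; no number sets it apart from compound 1.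

Compound 3 `COC(=O)c1cc(-c2cccc(NC(=O)c3ccc(/C=C/C(=O)c4ccc(C)c([N+](=O)[O-])c4)cc3)c2)on1` differs from compound 2 in one place: 4-methyl-3-nitrophenyl in place of 3-bromophenyl on a carbonyl carbon. Going by the values given here, the only measured step touches the same carbonyl carbon, but the two limits hide its size, so no direction can be expected in this assay beyond the scatter; a 4-methyl-3-nitrophenyl group at that position has not been measured here. Compound 3 is expected to sit near the limit as well, estimated at 100 ug/mL, within 40 ug/mL to 200 ug/mL. This expected step a number no higher from compound 2 to compound 3 (the limit leaves the size open) amounts to nothing beyond the scatter.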

Compound 3, half-maximal cytotoxic concentration: > 80 ug/mL
Compound 3: no number, only a limit; the forecaster's own chance of this, stated with the estimate: 70%; the middle value is on the limit's open side.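

In this assay compound 3 gives only a limit, > 80 ug/mL. For the compounds shown here, compound 1 and compound 2 also stand at limits, so no step among the three compounds can be read. The compounds shown leave open how much of each one the cells tolerate, and whether the group on the carbonyl carbon changes that at all.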